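The source may hold more compounds than are shown below. What is called first, only, known or untested is meant among the compounds shown, and "the series" means these compounds.

Compound 1 `O=S(=O)(c1ccccc1)c1nc2ccccc2nc1Nc1ccc(C(F)(F)F)cc1` and compound 2 `COc1ccc(S(=O)(=O)c2nc3ccccc3nc2Nc2ccc(C(F)(F)F)cc2)cc1` share a core and differ only where (methoxy in place of hydrogen on an aromatic carbon). In a functional assay on HL-60 cells (Homo sapiens) for cytotoxicity, read by MTT assay, with a stated time of 72 h (a lower number here means a stronger inhibitor, a higher number a weaker inhibitor), compound 1 gives 300 nM, and compound 2 gives 220 nM, so that a 1.4-fold lower number from compound 1 to compound 2 (0.13 log units; within the scatter). Compound 3 `COc1cc(Nc2nc3ccccc3nc2S(=O)(=O)c2ccc(F)cc2)cc(OC)c1` has a different core; the difference between the two cores is not broken down here. In this assay compound 3 gives 2360 nM, the highest of the three numbers and beyond the scatter from both compound 1 and compound 2. Compound 4 `COc1cc(Nc2nc3ccccc3nc2S(=O)(=O)c2ccc(F)cc2)cc(OC)c1OC`, which has not yet been measured in this assay, differs from compound 3 in that (methoxy in place of hydrogen on an aromatic carbon). This is the same kind of change as that from compound 1 to compound 2, though not the same: in compound 4 the entering methoxy is ortho to two methoxy groups as well as para to a large group, whereas in compound 2 it is only para to a large group. Since the earlier step, a 1.4-fold lower number from compound 1 to compound 2 (0.13 log units; within the scatter), stayed within the scatter, the step from compound 3 to compound 4 is expected to be of similar size, a 1.2-fold lower number from compound 3 to compound 4 (0.07 log units; within the scatter). Compound 4 is therefore estimated at 2000 nM, expected to lie between 800 nM and 5000 nM.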

Compound 4, half-maximal inhibitory concentration: 4790 nM
For compound 4 the middle estimate is 2.4-fold (0.38 log units) below the measured one, within the range that was stated.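

Placing a methoxy group on the aromatic carbon gives, in this assay, a 2.0-fold higher number from compound 3 to compound 4 (0.31 log units; beyond the scatter), a modest step in the direction of a weaker inhibitor. This change therefore does not carry over with the same size and direction from one core to the other: the same change on two cores in this assay, a 1.4-fold lower number (0.13 log units; within the scatter) from compound 1 to compound 2 and a 2.0-fold higher number (0.31 log units; beyond the scatter) from compound 3 to compound 4, 2.8-fold (0.44 log units) apart, beyond the scatter of two such steps. What this does not show is why the two steps part, since the cores differ and the entering methoxy group in compound 4 is ortho to two methoxy groups, and two pairs of compounds cannot separate these differences or support a rule for the whole series.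

The compounds shown leave open whether the gap follows the core or the two neighbouring methoxy groups, which could be read from the same change on the core of compound 1 with two methoxy groups ortho to the entering group. They also leave open how an amine, a hydroxyl group or a longer chain such as ethoxy in the same place would compare with methoxy on each core.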